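The compounds below may be only part of what the source reports. "The series", "measured", "known", "first", "only" and "open" are said of these compounds alone.

Compounds measured so far:
- compound 1, `Cc1cc(S(=O)(=O)N2CCCC(Cn3ccnc3)C2)ccc1F`: 24 nM
- compound 2, `O=S(=O)(c1ccc(F)c(Cl)c1)N1CCCC(Cn2ccnc2)C1`: 14 nM

In an assay on isolated protein for inhibition of Aromatase (Homo sapiens), read by fluorescence (on this read-out higher numbers stand for weaker inhibition and lower numbers for stronger inhibition), compound 2 gives 14 nM, and compound 1 gives 24 nM. The two numbers are separated only by the step of a 1.7-fold lower number from compound 1 to compound 2 (0.23 log units; within the scatter), which lies within the scatter, so the two compounds cannot be told apart on the numbers shown.

Compound 3, `O=S(=O)(c1ccc(F)c(F)c1)N1CCCC(Cn2ccnc2)C1`, differs from compound 2 by fluoro in place of chloro on an aromatic carbon. Among the measured compounds shown here, the single measured step that bears on this change is a 1.7-fold lower number from compound 1 to compound 2 (0.23 log units; within the scatter), an exchange of one small group for another on an aromatic carbon, and it stayed within the scatter. A further exchange of the same kind, chloro for fluoro, is therefore expected to leave this assay essentially where it is, with no step beyond the scatter in either direction.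

Compound 3 is thus estimated at 20 nM, with a range from 8 nM to 50 nM. This estimate corresponds to an expected step of a 1.4-fold higher number from compound 2 to compound 3 (0.15 log units; within the scatter).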

Compound 3, half-maximal inhibitory concentration: 43 nM
Beside the measured number, compound 3's estimate is 2.2-fold (0.33 log units) below it, within the range that was stated.
By their numbers in this assay, from the lowest: compounds 2, 1 and 3 (each within the scatter of the next, the first and the last beyond it).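

In this assay, among the compounds shown here, the swap at this position on the aromatic ring, ortho to a fluoro group, gives the first step beyond the scatter (a 3.1-fold higher number from compound 2 to compound 3 (0.49 log units; beyond the scatter)) for fluoro in place of chloro. This shows that the position does not treat every small group alike, although the step is modest. Fluoro in place of methyl stays within the scatter (a 1.8-fold higher number from compound 1 to compound 3 (0.25 log units; within the scatter)), so compound 1 and compound 3 cannot be told apart, and only the pair of compound 2 and compound 3 separates on the numbers.

The compounds shown leave open how bromo, methoxy or an amine would read at this position. They also leave open whether the step between chloro and fluoro holds when the neighbouring fluoro group is exchanged for another group. Nothing measured here accounts for the difference between chloro and fluoro.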